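The source may hold more compounds than are shown below. What is called first, only, known or untested is meant among the compounds shown, and "the series" means these compounds.

Measured so far in a functional assay on MES-SA cells (Homo sapiens) for inhibition, with a stated time of 72 h, in the presence of a further agent that is not named here; on this read-out higher numbers stand for weaker inhibition and lower numbers for stronger inhibition:
compound 1, `CCOCc1cc(CN2CCCCC2)c(O)c2ncccc12`, gives 9120 nM
compound 2, `CC(C)OCc1cc(CN2CCCCC2)c(O)c2ncccc12`, gives 5750 nM
compound 3, `COCc1cc(CN2CCC(C)CC2)c(O)c2ncccc12`, gives 6460 nM

The three measured compounds lie close together in this assay; the gaps between compound 3 and each of the other two are within the usual scatter, so no order among them can be read from these numbers. For the measured compounds named here, the one change seen twice here is a methyl in place of hydrogen on a carbon next to the ether oxygen. From compound 1 to compound 2 it reads methyl in place of hydrogen on a saturated chain carbon bound to an oxygen on a saturated carbon and a saturated chain carbon and it made a 1.6-fold lower number from compound 1 to compound 2 (0.20 log units; within the scatter).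

Compound 4, `CCOCc1cc(CN2CCC(C)CC2)c(O)c2ncccc12`, is not yet measured. It differs from compound 3 by methyl in place of hydrogen on a saturated chain carbon bound to an oxygen on a saturated carbon. This is the same kind of change as from compound 1 to compound 2, but not the same: in compound 3 the carbon carrying the change is bound to an oxygen on a saturated carbon only, whereas in compound 1 it is bound to an oxygen on a saturated carbon and a saturated chain carbon. How the core of compound 3 differs from that of compound 1 is not broken down here.

For compound 4 in this assay a step of a 1.4-fold lower number from compound 3 to compound 4 (0.16 log units; within the scatter) is expected, resting on the small shift of a 1.6-fold lower number from compound 1 to compound 2 (0.20 log units; within the scatter) and on compound 3 at 6460 nM. Compound 4 is thus estimated at 4500 nM, between 2000 nM and 10000 nM.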

Compound 4, half-maximal inhibitory concentration: 4470 nM
The estimate for compound 4 lay 1.0-fold (0.00 log units) above the measured number; the range from low to high includes it.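

In this assay, methyl in place of hydrogen on a saturated chain carbon bound to an oxygen on a saturated carbon gives a 1.4-fold lower number from compound 3 to compound 4 (0.16 log units; within the scatter), and set beside the earlier case, the change reads alike on the two cores: the same change on two cores in this assay, a 1.6-fold lower number (0.20 log units; within the scatter) from compound 1 to compound 2 and a 1.4-fold lower number (0.16 log units; within the scatter) from compound 3 to compound 4, 1.1-fold (0.04 log units) apart, within the scatter of two such steps. This shows that the size of the step carried over from one core to the other, but each step on its own lies within the scatter, so neither establishes a real effect of the change, and two cores cannot speak for the whole series. Methyl in place of hydrogen on a saturated ring carbon gives a 2.0-fold lower number from compound 1 to compound 4 (0.31 log units; beyond the scatter), but this is a single case and says nothing about how that change would carry to another core.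

The compounds shown leave open how a longer chain, such as a butyl group, or a carboxylic acid or an amine would read in place of these small ether groups. They also leave open whether the same step holds in any assay other than this assay.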